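From sec-Butyl to Isobutyl at the Amine Nitrogen

The compounds below may be only part of what the source reports. "The series", "measured", "known", "first", "only" and "open" are said of these compounds alone.

Measured in an ADME assay on EA.hy 926 cells (Homo sapiens) for inhibition, read by sulforhodamine B assay, with a stated time of 72 h; a higher number here means a weaker inhibitor, a lower number a stronger inhibitor:
Compound 1 `CCC(C)NC(=C\C(=O)/C=C/c1ccc(OC(C)=O)c(OC)c1)/C=C/c1ccc(OC(C)=O)c(OC)c1`: > 25000 nM, a limit of the assay, not a number.
Compound 2 `C=CCNC(=C\C(=O)/C=C/c1ccc(O)c(OC)c1)/C=C/c1ccc(O)c(OC)c1`: > 25000 nM, likewise a limit.

Compound 1 stands at the edge of what this assay reports: its value is a limit only, and the same holds for (the limit of > 25000 nM in this assay, at which 2 of the 2 values shown sit). Compound 3 `COc1cc(/C=C/C(=O)/C=C(/C=C/c2ccc(OC(C)=O)c(OC)c2)NCC(C)C)ccc1OC(C)=O` differs from compound 1 by isobutyl in place of sec-butyl on an amine nitrogen. For the measured compounds named here, no measured pair shows a change of this kind, so no step beyond the usual scatter is expected in this assay in either direction. Compound 3 is therefore expected at 30000 nM, between 15000 nM and 80000 nM, most likely again reported only as a limit, amounting to an expected step that the limit leaves unreadable from compound 1 to compound 3.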

Compound 3, half-maximal inhibitory concentration: > 25000 nM
Compound 3: only a limit was reported; the forecaster's own chance of this, stated with the estimate: 85%; the middle value is on the limit's open side.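

For the compounds shown here, compound 3, like compound 1, is reported only as a limit, so no step between the two can be read: the limit of > 25000 nM in this assay, at which 3 of the 3 values shown sit. In this assay the compounds shown leave open whether isobutyl in place of sec-butyl on the amine nitrogen changes inhibition at all.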